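The compounds below may be only part of what the source reports. "The series", "measured", "known", "first", "only" and "open" are said of these compounds alone.

Measured compounds:
Compound 1 `CCc1nc(-c2ccc(Cl)cc2Cl)c(CC)nc1NC(CC)CC`: 0.283 h
Compound 2 `CCc1nc(-c2ccc(OC)cc2C(F)(F)F)c(CC)nc1NC(CC)CC`: 0.2 h
Compound 3 `CCc1nc(-c2ccc(OC)cc2O)c(CC)nc1NC(CC)CC`: 0.3 h

In an in vitro ADME assay on microsomes (Homo sapiens) for metabolic stability (a higher number here means that the compound lasts longer, a lower number that the compound disappears faster), the three compounds sit within the scatter of one another. Going by the values given here, compound 3 gives 0.3 h in this assay; the gap to compound 1 is negligible, and the one counted step, a 1.5-fold higher number from compound 2 to compound 3 (0.18 log units; within the scatter), does not rise above the scatter either. Nothing in these three numbers separates the aryl substituents from one another.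

Compound 4 `CCc1nc(-c2ccc(OC)cc2OC(F)(F)F)c(CC)nc1NC(CC)CC` differs from compound 3 in a single place: trifluoromethyl in place of hydrogen on an oxygen on an aromatic ring.

Among the compounds with values here, no measured step bears directly on this change. The step from compound 2 to compound 3 exchanges a trifluoromethyl for a hydroxy on an aromatic carbon, which is a different place and a different pair of groups; it stays within the scatter, and all three measured values lie close together. Against this background no step beyond the scatter is expected for compound 4 in this assay, that is no change at the digits printed from compound 3 to compound 4 (within the scatter).

The estimate for compound 4 is 0.3 h, with a range from 0.15 h to 0.6 h.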

Compound 4, half-life: 0.267 h
Compound 4: middle estimate off by 1.1-fold (0.05 log units), on the high side, within the range that was stated.
By their numbers in this assay, from the lowest: compounds 2, 4, 1 and 3 (each within the scatter of the next).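

Trifluoromethyl in place of hydrogen on an oxygen on an aromatic ring gives a 1.1-fold lower number from compound 3 to compound 4 (0.05 log units; within the scatter) in this assay and thus adds a change at this oxygen to the earlier change on the aromatic carbon. Exchanging the trifluoromethyl on the aromatic carbon for a trifluoromethoxy gives a 1.3-fold higher number from compound 2 to compound 4 (0.13 log units; within the scatter) in this assay and leaves hydroxy, trifluoromethyl and trifluoromethoxy at this place not told apart by these half-lives. No available evidence accounts for these small steps.

On these data alone, whether a nitrile, a carboxylic acid or a longer chain at this place would give a step beyond the scatter stays open. Also open, as far as these compounds go, is whether a change elsewhere on the shared core would move the half-life further than these changes on the aromatic ring do.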